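A few compounds are considered here, and "the series" means these few. Any claim that something is new, unique, unknown or untested is made for them only; others in the source may bear on it.

Measured compounds:
Compound 1, `Cc1ccc(-n2nc(C(=O)Nc3ccc(Oc4ncnc5c4ccn5C)cc3)c(C)cc2=O)cc1`: in a functional assay on PC-3 cells (Homo sapiens) for cytotoxicity, read by MTT assay, with a stated time of 72 h (on this read-out higher numbers stand for weaker inhibition and lower numbers for stronger inhibition), compound 1 gives > 60000 nM, which is a limit of the assay.
Compound 2, `Cc1cc(=O)n(-c2cccc(F)c2)nc1C(=O)Nc1ccc(Oc2ncnc3c2ccn3C)c(F)c1`: in this assay compound 2 gives 8990 nM.

Within the data shown here, compound 2 thus holds the only numerical value seen here; the other value is a limit. Compound 3, `Cc1ccc(-n2nc(C(=O)Nc3ccc(Oc4ncnc5c4ccn5C)c(F)c3)c(C)cc2=O)cc1`, is still to be measured. It differs from compound 2 by 4-methylphenyl in place of 3-fluorophenyl on an aromatic nitrogen. Among the measured compounds shown here, no measured pair covers this change, so its size cannot be read off directly. Compound 1, which also carries the 4-methylphenyl, sits at the limit of > 60000 nM in this assay, at which 1 of the 2 values shown sits, so a weakening beyond the scatter is expected. Compound 3 is therefore estimated to give 30000 nM in this assay, within 9000 nM to 90000 nM, a step of a 3.3-fold higher number from compound 2 to compound 3 (0.52 log units; beyond the scatter).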

Compound 3, half-maximal inhibitory concentration: 50500 nM
Compound 3: the middle estimate sits 1.7-fold (0.23 log units) below what was measured; measured number inside the range.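

In this assay, 4-methylphenyl in place of 3-fluorophenyl on the aromatic nitrogen gives a 5.6-fold higher number from compound 2 to compound 3 (0.75 log units; beyond the scatter), the first measured size for this change. Fluoro in place of hydrogen on the aromatic carbon gives an at least 1.1-fold lower number from compound 1 to compound 3 (0.07 log units; that floor lies within the scatter), so no gain from this fluoro can be claimed. The value of compound 1 is only a limit of the assay: the limit of > 60000 nM in this assay, at which 1 of the 3 values shown sits.

The compounds shown do not separate the loss of the fluoro from the gain of the methyl. They also leave open how an unsubstituted phenyl or an aminophenyl on this nitrogen would read.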